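Swapping the attached heterocycle on a shared lactone core

A few compounds are considered here, and "the series" means these few. Any claim that something is new, unique, unknown or untested is made for them only; others in the source may bear on it.

Measured so far:
compound 1 `NC1(CCn2cc(F)c(=O)[nH]c2=O)OC(=O)C(OCc2ccccc2)=C1OCc1ccccc1` — 42800 nM
compound 2 `O=C1O/C(=C\Cn2c(=O)[nH]c(=O)[nH]c2=O)C(OCc2ccccc2)=C1OCc1ccccc1` — 44800 nM

In a functional assay on HepG2 cells (Homo sapiens) for inhibition, read by MTT assay, with a stated time of 72 h (a lower number here means a stronger inhibitor, a higher number a weaker inhibitor), compound 1 gives 42800 nM, and compound 2 gives 44800 nM; the two numbers lie within the scatter of each other, so neither stands apart. Compound 3 `NC1(CCn2c(=O)[nH]c(=O)[nH]c2=O)OC(=O)C(OCc2ccccc2)=C1OCc1ccccc1` is not yet measured. It differs from compound 1 by a group of 9 heavy atoms (3 carbon, 3 nitrogen, 3 oxygen; one six-membered aromatic ring with 3 hetero atoms) in place of a group of 9 heavy atoms (4 carbon, 2 nitrogen, 2 oxygen, 1 fluorine; one six-membered aromatic ring with 2 hetero atoms), on a saturated chain carbon, two bonds along the chain from a saturated ring carbon. For the measured compounds named here, no step between measured compounds shares this change, and the group that enters is already present in compound 2 without any visible shift. The step of a 1.1-fold higher number from compound 1 to compound 3 (0.02 log units; within the scatter) is therefore expected to stay within the scatter. Compound 3 is estimated at 45000 nM, with a range of 15000 nM to 135000 nM.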

Compound 3, half-maximal inhibitory concentration: > 100000 nM
Compound 3 gave a limit, no number; the forecaster's own chance of this, stated with the estimate: 15%; at least 2.2-fold (0.34 log units) between middle value and limit.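

On the saturated chain carbon, two bonds along the chain from a saturated ring carbon, the group with one six-membered aromatic ring with 3 hetero atoms gives the first step shown in this assay: an at least 2.3-fold higher number from compound 1 to compound 3 (0.36 log units; beyond the scatter). Compound 3 gives > 100000 nM, which is a limit of the assay and not a number. For the compounds shown here, the earlier compounds offered no step, so only this pair shows that the group at this place can change the reading.

As far as these compounds go, how large the step truly is stays open: the limit of > 100000 nM in this assay, at which 1 of the 3 values shown sits. Also open is how an amine, a carboxylic acid or a longer chain at this place would read.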